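The source may report more compounds than this note shows. Statements on the series, on what has been measured and on what is new or still open speak of the compounds shown alone.

Compound 2 `Cc1cc(C(=O)N2CCCCc3ccccc32)ccc1CNC(=O)NCC(=O)OC(C)(C)C` gives 120 nM in a functional assay on HEK293 cells for agonist activity at Vasopressin V2 receptor (Homo sapiens), read by a luciferase reporter and cAMP accumulation; on this read-out higher numbers stand for an effect only at larger amounts of compound and lower numbers for an effect already at smaller amounts. Among the compounds with values here, its only measured neighbour is compound 1 `Cc1cc(C(=O)N2CCCCc3ccccc32)ccc1CNC(=O)NCC(=O)O`, which gives 180 nM; the step of a 1.5-fold lower number from compound 1 to compound 2 (0.18 log units; within the scatter) lies within the scatter, so the two compounds cannot be told apart on this read-out. Compound 3 `COC(=O)[C@@H]1CCCN1C(=O)NCc1ccc(C(=O)N2CCCCc3ccccc32)cc1C` differs from compound 2 by 2-(methoxycarbonyl)pyrrolidin-1-yl in place of ((tert-butoxycarbonyl)methyl)amino on a carbonyl carbon. Within the data shown here, the single measured step, the one from compound 1 to compound 2, touched only the ester end of the same side chain and stayed within the scatter; no measured step exchanges the open chain for a five-membered ring or removes the hydrogen-bond donor, so that part of the change is untested. Compound 3 is therefore expected to stay close to compound 2, with the estimated step of a 1.3-fold higher number from compound 2 to compound 3 (0.10 log units; within the scatter) not expected to exceed the scatter, though with wide uncertainty. The estimate for compound 3 is 150 nM, with a range from 40 nM to 600 nM.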

Compound 3, half-maximal effective concentration: 100 nM
Estimate against measurement, compound 3: 1.5-fold (0.18 log units) above, and the stated range covers the measured number.
By their numbers in this assay, from the lowest: compounds 3, 2 and 1 (each within the scatter of the next).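

On the carbonyl carbon, a five-membered ring can take the place of the open chain with no change that can be told from scatter: in this assay the exchange gives a 1.2-fold lower number from compound 2 to compound 3 (0.08 log units; within the scatter). Measured against the free acid, the exchange of (carboxymethyl)amino for 2-(methoxycarbonyl)pyrrolidin-1-yl gives a 1.8-fold lower number from compound 1 to compound 3 (0.26 log units; within the scatter), so the three compounds cannot be told apart on this read-out, even though compound 3 has no hydrogen-bond donor in this group. Nothing available gives a reason for this flat result.

As far as these compounds go, the ring, the lost donor and the defined stereocentre all enter together in compound 3, so their separate contributions remain open, as does the effect of the opposite arrangement at that stereocentre. Also open, from the compounds shown here alone, is whether an amine or a longer chain on the pyrrolidine ring, in place of the methoxycarbonyl group, would move the number beyond the scatter.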